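The source may report more compounds than this note shows. Statements on the series, on what has been measured and on what is new or still open speak of the compounds shown alone.

Measured compounds in a functional assay on SH-SY5Y cells (Homo sapiens) for cytotoxicity, read by MTT assay, with a stated time of 72 h; on this read-out lower numbers stand for stronger inhibition and higher numbers for weaker inhibition:
- compound 1 `CC1(C)OCC(Cn2cc(Cn3c4c(c5ccccc53)C(=O)c3c[n+]([O-])c5ccccc5c3C4=O)nn2)O1` gives 230 nM
- compound 3 `O=C1c2c[n+]([O-])c3ccccc3c2C(=O)c2c1c1ccccc1n2Cc1cn([C@H]2C[C@H](O)[C@@H](CO)O2)nn1` gives 620 nM
- compound 2 `O=C1c2c[n+]([O-])c3ccccc3c2C(=O)c2c1c1ccccc1n2Cc1cn(CC(O)CO)nn1` gives only a limit, > 1000 nM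

Compound 2 thus stands at the weak end of the three: the value is a limit of the assay, not a number (the limit of > 1000 nM in this assay, at which 1 of the 3 values shown sits), and an at least 4.3-fold higher number from compound 1 to compound 2 (0.63 log units; beyond the scatter) marks the loss from compound 1. The other steps are a 2.7-fold higher number from compound 1 to compound 3 (0.43 log units; beyond the scatter) and an at least 1.6-fold lower number from compound 2 to compound 3 (0.20 log units; that floor lies within the scatter), the last resting on a floor within the scatter.

Compound 4 `CN(C)CCCCn1c2c(c3ccccc31)C(=O)c1c[n+]([O-])c3ccccc3c1C2=O` is unmeasured. The change from compound 2 is 3-(dimethylamino)propyl in place of 1-(2,3-dihydroxypropyl)-1H-1,2,3-triazol-4-yl on a saturated chain carbon bound to an aromatic nitrogen. Both measured steps out of compound 1 show that 1,2-dihydroxyethyl or a 4-hydroxy-5-(hydroxymethyl)oxolan-2-yl group on the chain weakens this assay, while the acetonide of compound 1 holds it near its best number. Within the data shown here, compound 4 removes the 1-(2,3-dihydroxypropyl)-1H-1,2,3-triazol-4-yl entirely for 3-(dimethylamino)propyl, a change no measured pair covers. The expectation is a recovery toward the range of compound 3, with wide uncertainty: compound 4 is estimated at 600 nM (range 150 nM to 2500 nM), i.e. an expected step of an at least 1.6-fold lower number from compound 2 to compound 4 (0.22 log units; that floor lies within the scatter).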

Compound 4, half-maximal inhibitory concentration: 250 nM
For compound 4 the middle estimate is 2.4-fold (0.38 log units) above the measured one; measured number inside the range.
By their numbers in this assay, from the lowest: compounds 1 and 4 (each within the scatter of the next); then compound 3. At a limit, above all of these: compound 2.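

In this assay, 3-(dimethylamino)propyl in place of 1-(2,3-dihydroxypropyl)-1H-1,2,3-triazol-4-yl on a saturated chain carbon bound to an aromatic nitrogen gives an at least 4.0-fold lower number from compound 2 to compound 4 (0.60 log units; beyond the scatter). This step is only a floor, as the value of compound 2 is a limit of the assay and not a number: the limit of > 1000 nM in this assay, at which 1 of the 4 values shown sits. The earlier compounds shown here all kept the triazole and varied only what it carries, whereas compound 4 shows that this position tolerates its complete removal, with compound 1 at 230 nM and compound 4 at 250 nM lying within the scatter of each other.

Still open is whether the dimethylamino group or the absence of the triazole accounts for the step, since 4-(dimethylamino)butyl is the only chain without a triazole among these compounds. A plain butyl chain, a longer chain carrying the same amine, or a morpholine in place of the dimethylamino group would help separate these two readings.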